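This account rests on a few compounds, and the source may have more. Where it says the series, first, only, none or still open, it means among the compounds named here.

Compound 1 `COc1cccc(NC(=O)c2nnn(Cc3ccc(SC)cc3)c2N)c1`: > 50100 nM
Compound 2 `COc1cccc(NC(=O)c2nnn(Cc3ccc(C#N)cc3)c2N)c1`: > 50100 nM

Both compounds were tested in a toxicity assay on Vero cells (Chlorocebus sabaeus) for inhibition; on this read-out higher numbers stand for an effect only at larger amounts of compound and lower numbers for an effect already at smaller amounts. Compound 1 reached only the limit of the assay, > 50100 nM, and no number was obtained. Compound 2 likewise reached only the limit, > 50100 nM. Within the data shown here, the one measured step, a step that the two limits leave unreadable from compound 1 to compound 2, therefore has no readable size: both values sit at the limit of > 50100 nM in this assay, at which 2 of the 2 values shown sit. Compound 2 thus stands at the ceiling of the numbers shown, side by side with compound 1, and nothing separates the two.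

Compound 3 `COc1cccc(NC(=O)c2nnn(Cc3ccncc3)c2N)c1` has not yet been tested in this assay. It differs from compound 2 by pyridin-4-yl in place of 4-cyanophenyl on a saturated chain carbon bound to an aromatic nitrogen. Among the measured compounds shown here, the only step that bears on this change is the one from compound 1 to compound 2, and its size cannot be read, since both of its values sit at the limit of > 50100 nM in this assay, at which 2 of the 2 values shown sit. The expectation is accordingly that compound 3 again shows no effect within the tested range of this assay, which would mean an expected step of a number no higher from compound 2 to compound 3 (the limit leaves the size open). Compound 3 is therefore estimated at 50100 nM, within a range from 20000 nM to 120000 nM.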

Compound 3, half-maximal effective concentration in the Vero assay: > 50100 nM
Compound 3 was reported as a limit (the forecaster's own chance of this, stated with the estimate: 85%); the middle value lies on the limit itself.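

In the Vero assay compound 3 also reached only a limit, so the steps from compound 1 and from compound 2 to compound 3 cannot be read. In a physicochemical assay for solubility, read by nephelometry, at pH 7.4 (a lower number here means a less soluble compound, a higher number a more soluble compound), compound 2 gives 216000 nM. In the physicochemical assay compound 3 gives < 12000 nM, which is a limit of the assay. The compounds shown leave open at what concentration any of the three would show an effect in the Vero assay.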